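A few compounds are considered here, and "the series" means these few. Any claim that something is new, unique, unknown or untested is made for them only; others in the source may bear on it.

Values measured in a physicochemical assay for lipophilicity, read by HPLC, measured as octanol-water partition; on this read-out higher numbers stand for higher lipophilicity and lower numbers for lower lipophilicity:
- compound 1 `O=C(CSc1ncnc2c1cnn2-c1ccccc1Cl)Nc1ccccc1` gives 4.3
- compound 2 `CCCCC(Sc1ncnc2c1cnn2-c1ccccc1Cl)C(=O)Nc1nc(C)cs1` gives 6.4
- compound 3 `COCCC(Oc1ncnc2c1cnn2-c1ccccc1C)C(=O)Nc1ccc(C)cn1` gives 4.2

Compound 3 (4.2) stands within the scatter of compound 1 (4.3), while compound 2 (6.4) lies higher, beyond the scatter. Compound 4 `COCCC(Oc1ncnc2c1cnn2-c1ccccc1OC)C(=O)Nc1ccc(C)cn1` has methoxy in place of methyl on an aromatic carbon, ortho to a large group, 2-methylphenyl becoming 2-methoxyphenyl methoxy in place of methyl on an aromatic carbon in this one place. Among the compounds with values here, no two measured compounds differ in only one place, so the data offer no direct precedent. In this assay a small downward step within the scatter is expected. The expected change is a number 0.20 log units lower from compound 3 to compound 4 (within the scatter) and remains only an estimate. Compound 4 is estimated at 4 (range 3.6 to 4.4).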

Compound 4, distribution coefficient: 3.5
Beside the measured number, compound 4's estimate is 0.50 log units above it; the whole stated range lies above it.
By their numbers in this assay, from the lowest: compound 4; then compounds 3 and 1 (each within the scatter of the next); then compound 2.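

In this assay, within the data shown here, methoxy in place of methyl on an aromatic carbon, ortho to a large group, gives a number 0.70 log units lower from compound 3 to compound 4 (beyond the scatter) and so provides the first reading of a change made in one place. Among these compounds, it shows that this position is not silent to this change, which the earlier compounds, differing in several places at once, could not show. Nothing shown gives a cause for the step. The compounds shown leave open whether ethoxy or an amine in this same place would move the number further, and whether 2-methylphenyl to 2-methoxyphenyl gives a step of like size in another compound.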